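Allyl in place of 2,2,2-trichloroethyl: series notes

A few compounds are considered here, and "the series" means these few. Any claim that something is new, unique, unknown or untested is made for them only; others in the source may bear on it.

Measured in a toxicity assay on HUVEC cells (Homo sapiens) for inhibition; on this read-out lower numbers stand for stronger inhibition of growth and higher numbers for weaker inhibition of growth:
- compound 1 `CCOC(=O)c1ccsc1NC(=O)[C@@H]1CCCN1`: > 250 ug/mL (a limit)
- compound 2 `O=C(OC1CCCCC1)c1ccsc1NC(=O)[C@@H]1CCCN1`: 137 ug/mL
- compound 3 `O=C(OCC(Cl)(Cl)Cl)c1ccsc1NC(=O)[C@@H]1CCCN1`: > 250 ug/mL (a limit)

Compound 3 gives no number, only a limit: the limit of > 250 ug/mL in this assay, at which 2 of the 3 values shown sit. The next compound, compound 4 `C=CCOC(=O)c1ccsc1NC(=O)[C@@H]1CCCN1`, differs from it as follows: vinyl in place of trichloromethyl on a saturated chain carbon bound to an oxygen next to a carbonyl group. Among the compounds with values here, three measured steps bear on this change: a step that the two limits leave unreadable from compound 1 to compound 3, an at least 1.8-fold lower number from compound 1 to compound 2 (0.26 log units; that floor lies within the scatter) and an at least 1.8-fold higher number from compound 2 to compound 3 (0.26 log units; that floor lies within the scatter). None of them is shown to lie beyond the scatter. The expectation rests mainly on compound 1, which stands at > 250 ug/mL, a limit. No step beyond the scatter is therefore expected in this assay. The expected step is a number no higher from compound 3 to compound 4 (the limit leaves the size open). Compound 4 is estimated at 250 ug/mL, with an expected range of 130 ug/mL to 500 ug/mL.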

Compound 4, concentration for 50% growth inhibition: 149 ug/mL
Beside the measured number, compound 4's estimate is 1.7-fold (0.22 log units) above it; low and high end bracket the measured number.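

In this assay, allyl at this position gives a number, as cyclohexyl does, while ethyl and 2,2,2-trichloroethyl give only limits: the limit of > 250 ug/mL in this assay, at which 2 of the 4 values shown sit. The steps from those two limits are an at least 1.6-fold lower number from compound 3 to compound 4 (0.22 log units; that floor lies within the scatter) and an at least 1.6-fold lower number from compound 1 to compound 4 (0.22 log units; that floor lies within the scatter), so neither shows a separation beyond the scatter. Against cyclohexyl the step is a 1.1-fold higher number from compound 2 to compound 4 (0.04 log units; within the scatter), so allyl and cyclohexyl cannot be told apart here.

From the compounds shown here alone, how far compound 1 and compound 3 truly lie from the other two stays open. Also open, going by these compounds, is how an amine or a carboxylic acid at this position would read.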